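Swapping a Bicyclic Amide Group for a Hydroxyphenyl Ring

This account rests on a few compounds, and the source may have more. Where it says the series, first, only, none or still open, it means among the compounds named here.

Three compounds share one core and differ only in the group carried on the amide-type nitrogen. Compound 1 `COc1ccc(NC(=O)[C@H]2CCCN2C(=O)C2(c3cccc(Cl)c3)CCCC2)nc1` gives 2 nM in an assay on isolated protein for inhibition of histone acetyltransferase p300 (Homo sapiens), with a stated time of 60 min; a lower number here means a stronger inhibitor, a higher number a weaker inhibitor. Compound 2 `O=C(Nc1ccc2[nH]ncc2n1)[C@H]1CCCN1C(=O)C1(c2cccc(Cl)c2)CCCC1` gives 0.159 nM in this assay, the lowest of the three numbers. Compound 3 `N#Cc1ccc(C2(C(=O)N3CCC[C@@H]3C(=O)Nc3ccc4[nH]ncc4n3)CCC2)cc1` gives 0.251 nM in this assay, which lies within the scatter of compound 2. Compound 1 sits furthest from compound 2, as the step of a 13-fold lower number from compound 1 to compound 2 (1.10 log units; beyond the scatter) shows. Compound 4 `O=C(Nc1ccc(O)cc1)[C@H]1CCCN1C(=O)C1(c2cccc(Cl)c2)CCCC1` has not yet been measured. The change is a group of 7 heavy atoms (6 carbon, 1 oxygen; one six-membered aromatic ring of carbon only) in place of a group of 9 heavy atoms (6 carbon, 3 nitrogen; one five-membered aromatic ring with 2 hetero atoms, one six-membered aromatic ring with 1 hetero atom), on an amide-type nitrogen. Going by the values given here, only one measured step touches this position, the one from compound 1 to compound 2, and it was large: the step of a 13-fold lower number from compound 1 to compound 2 (1.10 log units; beyond the scatter) shows how much the bicyclic group is worth against a single six-membered ring, so a single ring in compound 4 is expected to give a clearly higher number. The expected step is a 31-fold higher number from compound 2 to compound 4 (1.50 log units; beyond the scatter). Compound 4 is therefore estimated at 5 nM, with a range from 1 nM to 30 nM.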

Compound 4, half-maximal inhibitory concentration: 0.631 nM
Beside the measured number, compound 4's estimate is 7.9-fold (0.90 log units) above it; the measured number lies below the stated range.
By their numbers in this assay, from the lowest: compounds 2 and 3 (each within the scatter of the next); then compound 4; then compound 1.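

Exchanging 5-methoxypyridin-2-yl for 4-hydroxyphenyl gives a 3.2-fold lower number from compound 1 to compound 4 (0.50 log units; beyond the scatter), so single rings on the amide-type nitrogen are not interchangeable, and the size of the earlier step from compound 1 to compound 2 did not apply to every single ring. The bicyclic group still gives the lower number, with a 4.0-fold higher number from compound 2 to compound 4 (0.60 log units; beyond the scatter), but a ring of carbon only, carrying a hydroxyl group, recovers part of the ground between compound 1 and compound 2. No measurement available here accounts for either difference. On these data alone, it remains open how a plain phenyl ring, or a phenyl ring with an amine or a methoxy group in place of the hydroxyl, would compare on this nitrogen. Also open, as far as these compounds go, is how 4-hydroxyphenyl would behave on the core of compound 3.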